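The source may hold more compounds than are shown below. What is called first, only, known or untested is meant among the compounds shown, and "the series" means these compounds.

Measured so far in an assay on mitochondria from L6 cells (Rattus norvegicus) for activation, with a stated time of 90 min; on this read-out lower numbers stand for an effect already at smaller amounts and higher numbers for an effect only at larger amounts of compound:
compound 1 `Oc1nc2nonc2nc1Nc1ccc(F)cc1`: 38600 nM
compound 2 `Oc1nc2nonc2nc1Nc1ccc(OC(F)F)cc1`: 20600 nM

For the measured compounds named here, of these two numbers compound 2 is the one counted lowest, but the only step so far, a 1.9-fold lower number from compound 1 to compound 2 (0.27 log units; within the scatter), lies within the scatter, so compounds 1 and 2 cannot be told apart on these data.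

Compound 3 `Oc1nc2nonc2nc1Nc1ccc(OC(F)(F)C(F)F)cc1` is not yet measured. It differs from compound 2 by difluoromethyl in place of hydrogen on a saturated chain carbon bound to two fluorine atoms and an oxygen on an aromatic ring. Going by the values given here, the single step with any bearing is the one from compound 1 to compound 2, where growing the substituent on the aromatic ring from fluoro to difluoromethoxy gave a 1.9-fold lower number from compound 1 to compound 2 (0.27 log units; within the scatter), a shift within the scatter. Extending the same substituent further is therefore expected to give no step beyond the scatter; the step of a 1.3-fold lower number from compound 2 to compound 3 (0.11 log units; within the scatter) is the expected size. On that basis compound 3 is estimated at 16000 nM, with a range of 6000 nM to 42000 nM.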

Compound 3, half-maximal effective concentration: 7000 nM
Compound 3: middle estimate off by 2.3-fold (0.36 log units), on the high side; the range from low to high includes it.
By their numbers in this assay, from the lowest: compound 3; then compounds 2 and 1 (each within the scatter of the next).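

In this assay, for the compounds shown here, the difluoromethyl on a saturated chain carbon bound to two fluorine atoms and an oxygen on an aromatic ring gives a 2.9-fold lower number from compound 2 to compound 3 (0.47 log units; beyond the scatter) and is the first change to pass the scatter, so the number does respond to the substituent at this place. Taken as a whole, 1,1,2,2-tetrafluoroethoxy in place of fluoro on an aromatic carbon gives a 5.5-fold lower number from compound 1 to compound 3 (0.74 log units; beyond the scatter) and remains a modest change, with compound 3 lowest of the three. Nothing measured here accounts for the shift.

An unfluorinated ethoxy group and a longer fluorinated chain would be needed to tell whether the fluorine atoms or the chain length goes with the lower number. On these data alone, whether an amine or a carboxylic acid on the same aromatic carbon would give a similar number also remains open.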